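The source may report more compounds than this note shows. Statements on the series, on what has been measured and on what is new or still open speak of the compounds shown alone.

In a functional assay on HL-60 cells (Homo sapiens) for cytotoxicity, read by WST assay, with a stated time of 48 h (a higher number here means that more compound is needed for the effect, a lower number that less compound is needed), compound 1 (`O=C1OC[C@H](Cc2ccccc2)[C@H]1Cc1ccccc1`) gives 77000 nM and stands level, within the scatter, with compound 2 (`Cc1ccccc1C[C@H]1C(=O)OC[C@@H]1Cc1ccccc1`) at 57000 nM and compound 3 (`O=C1OC[C@H](Cc2ccccc2)[C@H]1Cc1ccccc1F`) at 72000 nM on these numbers. The change to compound 4 (`O=C1OC[C@H](Cc2ccccc2)[C@H]1Cc1cccc(OC(F)(F)F)c1`) is trifluoromethoxy in place of hydrogen on an aromatic carbon and amounts to trifluoromethoxy in place of hydrogen on an aromatic carbon, meta to a large group. Among the compounds with values here, two measured steps bear on it: methyl in place of hydrogen gives a 1.4-fold lower number from compound 1 to compound 2 (0.13 log units; within the scatter) and fluoro in place of hydrogen gives a 1.1-fold lower number from compound 1 to compound 3 (0.03 log units; within the scatter) and both stay within the scatter, so no step beyond the scatter is expected in this assay for compound 4. Within the data shown here, no measured compound carries trifluoromethoxy, and these two steps are only a loose guide, which keeps the range wide. The estimated step is a 1.4-fold lower number from compound 1 to compound 4 (0.15 log units; within the scatter) at the middle of the range. Compound 4 is expected at 55000 nM with an estimated range of 22000 nM to 110000 nM in this series.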

Compound 4, half-maximal effective concentration: 34000 nM
Compound 4: the middle estimate sits 1.6-fold (0.21 log units) above what was measured; the measured number falls inside the stated range.
By their numbers in this assay, from the lowest: compounds 4, 2, 3 and 1 (each within the scatter of the next, the first and the last beyond it).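

In this assay, within the data shown here, trifluoromethoxy on an aromatic carbon, meta to a large group, gives the first step that lies beyond the scatter: a 2.3-fold lower number from compound 1 to compound 4 (0.36 log units; beyond the scatter). Among these compounds, the steps to compound 2 and compound 3 stayed within the scatter, so this change is the first sign that substitution on this aromatic ring can move the number, though the step is modest and compound 4 still needs 34000 nM. Nothing available explains this step.

The compounds shown leave open whether the step belongs to the trifluoromethoxy group itself or to its place on the ring. Also open, as far as these compounds go, is how a methoxy, a trifluoromethyl or an amine at this same place would compare, and whether trifluoromethoxy on the other aromatic ring would give a similar step.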